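Ester variation on the shared core: expectation for compound 4

The compounds below may be only part of what the source reports. "The series", "measured", "known", "first", "only" and "open" are said of these compounds alone.

Compound 1 `C=C1C(=O)O[C@H]2CC3=C[C@H](C/C(C)=C/[C@@H](OC(=O)c4ccc(C(C)=O)cc4)[C@H]12)OC3=O`: 2300 nM
Compound 2 `C=C1C(=O)O[C@H]2CC3=C[C@H](C/C(C)=C/[C@@H](OC(=O)/C=C/c4ccc(N(C)C)cc4)[C@H]12)OC3=O`: > 10000 nM, a limit of the assay
Compound 3 `C=C1C(=O)O[C@H]2CC3=C[C@H](C/C(C)=C/[C@@H](OC(=O)/C=C/c4ccc(C(F)(F)F)cc4)[C@H]12)OC3=O`: 5900 nM

In a functional assay on A549 cells (Homo sapiens) for cytotoxicity, read by MTT assay, with a stated time of 48 h (a lower number here means a stronger inhibitor, a higher number a weaker inhibitor), compound 1 gives 2300 nM, the lowest of the two numbers shown. Compound 3 gives 5900 nM, a higher number beyond the scatter. Compound 2 reaches only (the limit of > 10000 nM in this assay, at which 1 of the 3 values shown sits). The ester change from compound 1 gave an at least 4.3-fold higher number from compound 1 to compound 2 (0.63 log units; beyond the scatter), and the aromatic substituent change gave an at least 1.6-fold lower number from compound 2 to compound 3 (0.22 log units; that floor lies within the scatter), so both ethenyl-linked esters sit at higher numbers than compound 1. Compound 4 `C=C1C(=O)O[C@H]2CC3=C[C@H](C/C(C)=C/[C@@H](OC(=O)/C=C/c4cccs4)[C@H]12)OC3=O` differs from compound 1 by 2-(thiophen-2-yl)ethenyl in place of 4-acetylphenyl on a carbonyl carbon. On this basis compound 4 is expected to show a higher number, a 2.4-fold higher number from compound 1 to compound 4 (0.38 log units; beyond the scatter). The estimate for compound 4 in this assay is 5500 nM, with a range of 2500 nM to 12000 nM.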

Compound 4, half-maximal inhibitory concentration: 4300 nM
Compound 4: middle estimate off by 1.3-fold (0.11 log units), on the high side, and the stated range covers the measured number.
By their numbers in this assay, from the lowest: compounds 1, 4 and 3 (each within the scatter of the next, the first and the last beyond it). At a limit, above all of these: compound 2.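

In this assay, an ethenyl-linked ester on the shared core can stay within the scatter of the 4-acetylphenyl ester: a 1.9-fold higher number from compound 1 to compound 4 (0.27 log units; within the scatter). On the ethenyl link, thiophen-2-yl in place of 4-(trifluoromethyl)phenyl also stays within the scatter, a 1.4-fold lower number from compound 3 to compound 4 (0.14 log units; within the scatter), while thiophen-2-yl in place of 4-(dimethylamino)phenyl gives a step beyond it, an at least 2.3-fold lower number from compound 2 to compound 4 (0.36 log units; beyond the scatter). Compound 2 stands at a limit of the assay: the limit of > 10000 nM in this assay, at which 1 of the 4 values shown sits.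

The compounds shown leave open how 4-acetylphenyl itself behaves on the ethenyl link. Also open, on these data alone, is how this ester position responds to a pyridine ring, a carboxylic acid or a longer saturated chain.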